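The source may hold more compounds than are shown below. What is called first, only, known or untested is meant among the compounds shown, and "the series" means these compounds.

Working notes on the series. In a functional assay on isolated protein for agonist activity at Glucose-dependent insulinotropic receptor (Homo sapiens), read by HTRF and cAMP accumulation (on this read-out higher numbers stand for an effect only at larger amounts of compound and lower numbers for an effect already at smaller amounts), compound 1 `CC(C)(C)OC(=O)N1CCC(O[C@H]2CC[C@H](Oc3ccc(C#N)cc3)CC2)CC1` gives 8.6 nM, the lowest of the two numbers in hand; compound 2 `CC(C)OC(=O)N1CCC(O[C@H]2CC[C@H](Oc3ccc(S(C)(=O)=O)nc3)CC2)CC1` gives 13 nM in this assay, and the two values fall within the scatter of each other, so no order between them is claimed. Compound 3 `CC(C)(C)OC(=O)N1CCC(O[C@H]2CC[C@H](Oc3cnc(C#N)cn3)CC2)CC1` is not yet measured; it differs from compound 1 by 5-cyanopyrazin-2-yl in place of 4-cyanophenyl on an oxygen on a saturated carbon. Within the data shown here, with no measured step of this kind available, the expectation for compound 3 rests only on compound 1 and compound 2, and a step from compound 1 to compound 3 of a 1.7-fold higher number from compound 1 to compound 3 (0.24 log units; within the scatter) is expected, small and not clearly beyond the scatter. Compound 3 is estimated at 15 nM in this assay, within a range of 5 nM to 50 nM.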

Compound 3, half-maximal effective concentration: 8.3 nM
Estimate against measurement, compound 3: 1.8-fold (0.26 log units) above, and the stated range covers the measured number.
By their numbers in this assay, from the lowest: compounds 3, 1 and 2 (each within the scatter of the next).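

Working across this position, on an oxygen on a saturated carbon, 5-cyanopyrazin-2-yl in place of 4-cyanophenyl gives a 1.0-fold lower number from compound 1 to compound 3 (0.02 log units; within the scatter) in this assay. An aromatic ring with 2 hetero atoms therefore reads the same here as one of carbon only, which compound 2 could not show, as it differs from compound 1 in more than one place. Nothing measured bears on why the two groups read alike.

Open, from the compounds shown here alone, is whether the nitrile is needed at all, which a carboxylic acid or an amine in its place on the ring would address. One pair also leaves open whether this exchange reads the same with other groups on the core.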